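Second Methyl on the Ring Carbon of a 5-Lipoxygenase Inhibitor

The source may report more compounds than this note shows. Statements on the series, on what has been measured and on what is new or still open speak of the compounds shown alone.

Compound 1, `CC1Oc2ccc(Oc3ccccc3)cc2C=C1CN(O)C(N)=O`, in an assay (Cavia porcellus) for inhibition of Polyunsaturated fatty acid 5-lipoxygenase (Homo sapiens) (a higher number here means a weaker inhibitor, a lower number a stronger inhibitor), gives 87 nM.
Compound 2, `CCCC1Oc2ccc(Oc3ccccc3)cc2C=C1CN(O)C(N)=O`, in this assay gives 870 nM.
Compound 3, `NC(=O)N(O)CC1=Cc2cc(Oc3ccccc3)ccc2OC1c1ccccc1`, in this assay gives 320 nM.

Compound 1 stands lowest of the three numbers in this assay; compound 3 is nearest, and compound 2 furthest. Both of the measured steps that start from compound 1 run in the same direction: a 10-fold higher number from compound 1 to compound 2 (1.00 log units; beyond the scatter), and a 3.7-fold higher number from compound 1 to compound 3 (0.57 log units; beyond the scatter). Between compound 2 and compound 3 the step is a 2.7-fold lower number from compound 2 to compound 3 (0.43 log units; beyond the scatter), so phenyl on the ring carbon sits between methyl and the propyl chain in this series.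

Compound 4, `CC1(C)Oc2ccc(Oc3ccccc3)cc2C=C1CN(O)C(N)=O`, is not yet measured. It differs from compound 1 by methyl in place of hydrogen on a saturated ring carbon, so that ring carbon then carries a second methyl. Both bearing steps show that growth around this carbon, whether by lengthening the chain or by exchanging methyl for phenyl, raised the number in this assay by a modest amount. A single added methyl is a smaller change than either, so compound 4 is expected to give a number above that of compound 1, with the step of a 2.9-fold higher number from compound 1 to compound 4 (0.46 log units; beyond the scatter) estimated as modest. Compound 4 is estimated at 250 nM, within a range from 90 nM to 800 nM.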

Compound 4, half-maximal inhibitory concentration: 440 nM
Beside the measured number, compound 4's estimate is 1.8-fold (0.25 log units) below it, and the stated range covers the measured number.
By their numbers in this assay, from the lowest: compound 1; then compounds 3, 4 and 2 (each within the scatter of the next, the first and the last beyond it).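

Compounds 1, 2 and 3 all keep a hydrogen on this saturated ring carbon and vary only the group that stands with it, so they say nothing about that hydrogen itself. The new step, a 5.1-fold higher number from compound 1 to compound 4 (0.70 log units; beyond the scatter) in this assay, shows that the hydrogen also matters: putting a methyl in its place, without removing the methyl already there, raises the number beyond the scatter. A single methyl thus lifts the number to within the scatter of compound 3 and of compound 2, and every change at this carbon shown so far gives a higher number than compound 1, with none going against that pattern; nothing at hand explains why the second methyl has this effect.

The compounds shown leave open whether a group on this carbon can give a number lower than that of compound 1, for instance fluorine or hydroxyl in place of the hydrogen, or hydrogen in place of the existing methyl. They also leave open how an ethyl group, or a cyclopropane ring built on this carbon, would compare with the two methyl groups of compound 4.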